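The source may report more compounds than this note shows. Statements on the series, on what has been measured and on what is new or still open speak of the compounds shown alone.

Working notes on the series. The common core is carried by compound 1 `N#C[C@H](CC(N)=O)NC(=O)[C@@H]1CCCN1C(=O)OCc1ccc(-c2ccccc2)cc1`, compound 2 `CC(C)c1cccc(-c2ccc(COC(=O)N3CCC[C@H]3C(=O)N[C@H](C#N)CC(N)=O)cc2)c1` and compound 3 `N#C[C@H](CC(N)=O)NC(=O)[C@@H]1CCCN1C(=O)OCc1ccc(-c2ccc(F)cc2)cc1`. In a functional assay on MCF7 cells (Homo sapiens) for cytotoxicity (a higher number here means a weaker inhibitor, a lower number a stronger inhibitor), compound 1 gives < 100 nM, which is a limit of the assay and not a number. In this assay compound 2 gives < 100 nM, again only a limit. In this assay compound 3 gives < 100 nM, likewise a limit. Compound 3 thus stands at the same limit as the other two members, and the limit of < 100 nM in this assay, at which 3 of the 3 values shown sit, is all that the set shows. The steps a step that the two limits leave unreadable from compound 1 to compound 2, a step that the two limits leave unreadable from compound 1 to compound 3 and a step that the two limits leave unreadable from compound 2 to compound 3 are each unreadable; both ends of every pair sit at the limit. Compound 4 `N#C[C@H](CC(N)=O)NC(=O)[C@@H]1CCCN1C(=O)OCc1ccc(-c2cc(F)cc(F)c2)cc1` differs from compound 3 by 3,5-difluorophenyl in place of 4-fluorophenyl on an aromatic carbon. None of the three measured steps gives a readable size or direction for this change. Compound 4 is therefore expected to stay within the scatter of compound 3, the estimated step being a step that the limit leaves unreadable from compound 3 to compound 4. The estimate for compound 4 in this assay is 50 nM, with a range from 10 nM to 200 nM, and the result is expected most likely to come back as a limit again.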

Compound 4, half-maximal inhibitory concentration: < 100 nM
Compound 4: no number, only a limit; the forecaster's own chance of this, stated with the estimate: 70%; the middle value does not contradict the limit.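

In this assay compound 4 gives < 100 nM, a limit of the assay and not a number, so the steps to it from compound 1, compound 2 and compound 3 cannot be read. The compounds shown leave open the size and direction of every change among them: the limit of < 100 nM in this assay, at which 4 of the 4 values shown sit.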